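Benzyl variations on the sulfur of a shared core

The source may hold more compounds than are shown below. What is called first, only, known or untested is meant among the compounds shown, and "the series" means these compounds.

Compound 2 `Cn1nc(-c2nnc(SCc3c(F)cccc3F)o2)cc1-c1ccc(C(F)(F)F)cc1` gives 26200 nM in a functional assay on MCF7 cells (Homo sapiens) for cytotoxicity, read by MTT assay, with a stated time of 24 h (a lower number here means a stronger inhibitor, a higher number a weaker inhibitor), the lower of the two numbers reported, though compound 3 `Cn1nc(-c2nnc(SCc3ccc(Cl)c(Cl)c3)o2)cc1-c1ccc(C(F)(F)F)cc1` gives 27200 nM and a 1.0-fold higher number from compound 2 to compound 3 (0.02 log units; within the scatter). Compound 1 `Cn1nc(-c2nnc(S)o2)cc1-c1ccc(C(F)(F)F)cc1` gives > 100000 nM, which is a limit of the assay. Both benzyl groups carry the series away from that limit: an at least 3.8-fold lower number from compound 1 to compound 2 (0.58 log units; beyond the scatter) and an at least 3.6-fold lower number from compound 1 to compound 3 (0.56 log units; beyond the scatter). Compound 4 `Cn1nc(-c2nnc(SCc3cccc([N+](=O)[O-])c3)o2)cc1-c1ccc(C(F)(F)F)cc1` differs from compound 2 by 3-nitrophenyl in place of 2,6-difluorophenyl on a saturated chain carbon bound to a sulfur. Among the measured compounds shown here, the only measured change of the same kind, a 1.0-fold higher number from compound 2 to compound 3 (0.02 log units; within the scatter), stayed within the scatter, and no other measured step bears on this swap. The expected step is therefore a 1.0-fold higher number from compound 2 to compound 4 (0.01 log units; within the scatter), none beyond the scatter. Compound 4 is estimated at 27000 nM, with a range from 9000 nM to 90000 nM.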

Compound 4, half-maximal inhibitory concentration: > 100000 nM
Compound 4 gave a limit, no number; the forecaster's own chance of this, stated with the estimate: 15%; middle value at least 3.7-fold (0.56 log units) away from the limit.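

In this assay, the group on the saturated chain carbon bound to a sulfur is not interchangeable: 3-nitrophenyl gives an at least 3.8-fold higher number from compound 2 to compound 4 (0.58 log units; beyond the scatter) and an at least 3.6-fold higher number from compound 3 to compound 4 (0.56 log units; beyond the scatter). The within-scatter match of compound 2 and compound 3 therefore does not extend to every benzyl group on this sulfur. The value of compound 4 is a limit, and the step from compound 1 to compound 4 cannot be read: the limit of > 100000 nM in this assay, at which 2 of the 4 values shown sit.

Still open, going by these compounds, is whether the nitro group itself or its 3-position on the benzyl group accounts for this step. A 3-chlorobenzyl or 3-aminobenzyl group on the same sulfur would bear on that.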